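Trifluoromethyl to Hydroxy on the Terminal Phenyl Ring

The compounds below may be only part of what the source reports. "The series", "measured", "known", "first", "only" and "open" are said of these compounds alone.

Compound 1 `COc1cc(NC(C)CCCNC(=O)NNC(=O)Nc2ccc(C(F)(F)F)cc2)c2ncccc2c1` was tested in a functional assay on NCI-H460 cells (Homo sapiens) for inhibition, read by MTT assay, with a stated time of 72 h (a lower number here means a stronger inhibitor, a higher number a weaker inhibitor), where compound 1 gives 12000 nM. Among the three compounds measured it holds the second highest number: compound 2 `COc1cc(NC(C)CCCNC(=O)Nc2cc(C(F)(F)F)cc(C(F)(F)F)c2)c2ncccc2c1` gives 8300 nM and compound 3 `COc1cc(NC(C)CCCNC(=O)Nc2cccc(C(F)(F)F)c2)c2ncccc2c1` gives 21000 nM, and both of these values lie within the scatter of that of compound 1. Among the compounds with values here, the only single-point step measured, a 2.5-fold higher number from compound 2 to compound 3 (0.40 log units; beyond the scatter), takes away a trifluoromethyl. Compound 4 `COc1cc(NC(C)CCCNC(=O)NNC(=O)Nc2ccc(O)cc2)c2ncccc2c1` differs from compound 1 by hydroxy in place of trifluoromethyl on an aromatic carbon. Within the data shown here, that change also removes a trifluoromethyl, so a modest weakening, as seen between compound 2 and compound 3, seems plausible, though the entering hydroxy has no measured counterpart here. Compound 4 is therefore expected to give 20000 nM, with a range from 8000 nM to 50000 nM. The expected step is a 1.7-fold higher number from compound 1 to compound 4 (0.22 log units; within the scatter).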

Compound 4, half-maximal inhibitory concentration: > 100000 nM
Compound 4: a limit, no number (the forecaster's own chance of this, stated with the estimate: 10%); at least 5.0-fold (0.69 log units) between middle value and limit.
By their numbers in this assay, from the lowest: compounds 2, 1 and 3 (each within the scatter of the next, the first and the last beyond it). At a limit, above all of these: compound 4.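

The earlier compounds shown here showed only a trifluoromethyl being taken away, whereas here a hydroxy enters in its place on the aromatic carbon, and the change gives an at least 8.3-fold higher number from compound 1 to compound 4 (0.92 log units; beyond the scatter). Compound 4 stands as a limit, not a number, in this assay: the limit of > 100000 nM in this assay, at which 1 of the 4 values shown sits. The step of an at least 4.7-fold higher number from compound 3 to compound 4 (0.67 log units; beyond the scatter) differs in more than the terminal substituent, so it does not isolate the hydroxy.

On these data alone, the full size of the change stays open. As far as these compounds go, whether leaving trifluoromethyl or entering hydroxy matters more also stays open, and hydrogen, methoxy or an amine on this carbon could separate the two.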